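A Benzothiophen-5-yl Analogue and Fibroblast Cytotoxicity

The compounds below may be only part of what the source reports. "The series", "measured", "known", "first", "only" and "open" are said of these compounds alone.

Measured in an ADME assay on cells (Fibroblast, Gallus gallus) for cytotoxicity, read by CCK-8 assay, with a stated time of 48 h; a lower number here means that less compound is tolerated, a higher number that more compound is tolerated:
- compound 1 `CCc1ccc(CN[C@H]2CC(C(=O)O)=C[C@@H](OC(CC)CC)[C@@H]2NC(C)=O)cc1`: > 200000 nM
- compound 2 `CCC(CC)O[C@@H]1C=C(C(=O)O)C[C@H](NCc2ccc(C(C)C)cc2)[C@H]1NC(C)=O`: > 200000 nM
- compound 3 `CCC(CC)O[C@@H]1C=C(C(=O)O)C[C@H](NCc2ccc(-c3csc4ccccc34)cc2)[C@H]1NC(C)=O`: > 200000 nM

Each of these three values is a limit of the assay rather than a number. Compound 2 therefore stands only at a limit, and the two other values around it are limits as well, so its position relative to compound 1 and compound 3 cannot be ranked. The steps among the measured compounds are accordingly unreadable: a step that the two limits leave unreadable from compound 1 to compound 2, a step that the two limits leave unreadable from compound 1 to compound 3 and a step that the two limits leave unreadable from compound 2 to compound 3. What the three share is the limit of > 200000 nM in this assay, at which 3 of the 3 values shown sit.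

Compound 4 `CCC(CC)O[C@@H]1C=C(C(=O)O)C[C@H](NCc2ccc(-c3ccc4sccc4c3)cc2)[C@H]1NC(C)=O` is not yet measured. It differs from compound 2 as follows: 1-benzothiophen-5-yl in place of isopropyl on an aromatic carbon. For the measured compounds named here, the step from compound 2 to compound 3, in which a benzothiophen-3-yl entered on the same aromatic carbon, did not move the read-out off the limit, and no measured step shows any change beyond the scatter. The expectation for this assay is therefore no readable step, a number no higher from compound 2 to compound 4 (the limit leaves the size open), with compound 4 again most likely sitting at the limit. Compound 4 is estimated at 200000 nM, with a range from 150000 nM to 300000 nM.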

Compound 4, half-maximal cytotoxic concentration: > 200000 nM
Compound 4 gave a limit, no number (the forecaster's own chance of this, stated with the estimate: 85%); the middle value lies on the limit itself.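

In this assay compound 4 gave only a limit and no number, so its steps from compound 1, compound 2 and compound 3 cannot be read: the limit of > 200000 nM in this assay, at which 4 of the 4 values shown sit. The compounds shown leave open how these four compounds rank against one another, and whether any group on that aromatic carbon would give a measurable number.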